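Branched aminoalkyl chain on the shared core

The source may hold more compounds than are shown below. What is called first, only, known or untested is meant among the compounds shown, and "the series" means these compounds.

In a functional assay on the whole organism with Mus musculus as the target (a lower number here means that less compound is needed, a higher number that more compound is needed for the effect), compound 3 `Cc1cc(-c2ccccc2)nnc1NCCCN` gives 0.1 mg/kg, level with compound 1 `Cc1cc(-c2ccccc2)nnc1NCCCCN` at 0.1 mg/kg; together these are the lowest of the three numbers, while compound 2 `CNCCNc1nnc(-c2ccccc2)cc1C` stands at 2 mg/kg. Compound 4 `Cc1cc(-c2ccccc2)nnc1NC(C)CN` differs from compound 3 by 1-(aminomethyl)ethyl in place of 3-aminopropyl on a nitrogen on an aromatic ring. For the measured compounds named here, two measured steps bear on this. Shortening the chain by one carbon gave no change at the digits printed from compound 1 to compound 3 (within the scatter), so the spacing between the two nitrogens is tolerant. Relocating a carbon onto the terminal nitrogen gave a 20-fold lower number from compound 2 to compound 3 (1.30 log units; beyond the scatter) in reverse, a large cost. Compound 4 rearranges the same atoms without substituting the terminal nitrogen, so a modest loss is expected. Compound 4 is estimated at 0.3 mg/kg, within 0.1 mg/kg to 1 mg/kg. This estimate implies an expected step of a 3.0-fold higher number from compound 3 to compound 4 (0.48 log units; beyond the scatter).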

Compound 4, minimum effective dose: 2 mg/kg
The estimate for compound 4 lay 6.7-fold (0.82 log units) below the measured number; measured number outside the range, above it.
By their numbers in this assay, from the lowest: compounds 1 and 3 (each within the scatter of the next); then compounds 2 and 4 (each within the scatter of the next).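

In (this assay), the branched 1-(aminomethyl)ethyl chain, with the same atoms as 3-aminopropyl and an unsubstituted terminal amine, carries a large penalty (a 20-fold higher number from compound 3 to compound 4 (1.30 log units; beyond the scatter)) and (a 20-fold higher number from compound 1 to compound 4 (1.30 log units; beyond the scatter)). Set against the 2-(methylamino)ethyl chain, it shows (no change at the digits printed from compound 2 to compound 4 (within the scatter)). The tolerance seen between 4-aminobutyl and 3-aminopropyl therefore does not extend to this rearrangement of the chain. Nothing available accounts for the loss. On these data alone, whether a 2-aminopropyl chain would keep the low number of compound 3 remains open, as does the effect of a dimethylamino end group.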